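A few compounds are considered here, and "the series" means these few. Any claim that something is new, unique, unknown or untested is made for them only; others in the source may bear on it.

Measured in a functional assay on MCF7 cells (Homo sapiens) for cytotoxicity, read by sulforhodamine B assay; on this read-out lower numbers stand for higher toxicity in this test and higher numbers for lower toxicity in this test:
- compound 1 `CC1=CC[C@@H]([C@@](C)(O)CCCC(C)(C)NC(=S)N/N=C\c2ccc(C)cc2)CC1`: > 100000 nM
- compound 2 `CC1=CC[C@@H]([C@@](C)(O)CCCC(C)(C)NC(=S)N/N=C\c2ccccc2[N+](=O)[O-])CC1`: > 100000 nM
- compound 3 `CC1=CC[C@@H]([C@@](C)(O)CCCC(C)(C)NC(=S)N/N=C\c2cccc([N+](=O)[O-])c2)CC1`: 47300 nM

Compound 1 gives a limit of this assay and not a number. Compound 2 gives the same kind of limit. The series therefore gives (the limit of > 100000 nM in this assay, at which 2 of the 3 values shown sit). Going by the values given here, compound 3 holds the only true number, and it is the one compound of the three that registers below that limit.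

The next compound, compound 4 `CC1=CC[C@@H]([C@@](C)(O)CCCC(C)(C)NC(=S)N/N=C\c2ccc([N+](=O)[O-])cc2)CC1`, differs from compound 3 in one place: 4-nitrophenyl in place of 3-nitrophenyl on a carbon with a double bond to nitrogen. Among the compounds with values here, two measured steps bear on this change. The closer one moves among the nitrophenyl groups and is an at least 2.1-fold lower number from compound 2 to compound 3 (0.32 log units; beyond the scatter). The other is an at least 2.1-fold lower number from compound 1 to compound 3 (0.32 log units; beyond the scatter). Both start from a limit, so each gives only a lower bound on its size, and a step that the two limits leave unreadable from compound 1 to compound 2 adds nothing. Nothing measured yet shows how the 4-nitrophenyl group behaves. Its closest measured relative is compound 3 at 47300 nM, so compound 4 is expected to stay weakly toxic and near that level. The estimate is a 1.2-fold higher number from compound 3 to compound 4 (0.07 log units; within the scatter), and no change beyond the scatter is expected. For compound 4 the expected value is 55000 nM, with an estimated range from 18000 nM to 100000 nM.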

Compound 4, concentration lethal to 50% of the cells: > 100000 nM
Compound 4 was reported as a limit; the forecaster's own chance of this, stated with the estimate: 35%; middle value at least 1.8-fold (0.25 log units) away from the limit.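

In this assay, 4-nitrophenyl in place of 3-nitrophenyl on a carbon with a double bond to nitrogen gives an at least 2.1-fold higher number from compound 3 to compound 4 (0.32 log units; beyond the scatter), so two compounds with the same atoms, joined differently, now separate beyond the scatter. Compound 4 gives > 100000 nM, which is a limit of this assay and not a number. Of the three nitrophenyl compounds, only compound 3 gives a true number, while compound 2 and compound 4 join compound 1 at the same limit, and the series now rests largely on that limit: the limit of > 100000 nM in this assay, at which 3 of the 4 values shown sit.

The steps to compound 4 from compound 1 and from compound 2 cannot be read, so neither the size of the change nor any order among these three compounds is known. From the compounds shown here alone, it also remains open whether the response seen with compound 3 depends on the nitro group itself or would persist with another group in its place on the phenyl ring, such as a nitrile, an amine or a carboxylic acid.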